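Swapping Ethyl for Acetamido: Expected Cytotoxicity of Compound 4

The compounds below may be only part of what the source reports. "The series", "measured", "known", "first", "only" and "open" are said of these compounds alone.

Of the compounds shown here, three built on one shared core have been tested in an ADME assay on L929 cells (Mus musculus) for cytotoxicity, read by resazurin assay, with a stated time of 72 h; a higher number here means a weaker inhibitor, a lower number a stronger inhibitor. Compound 1, `CCc1ccc(C(=O)/C=C/c2ccc3c(c2)B(O)OC3)cc1`, carries an ethyl group on a six-membered aromatic ring of carbon only. In this assay compound 1 reaches only a limit of the test, > 10 ug/mL, so no number is known for it. Compound 2, `O=C(/C=C/c1ccc2c(c1)B(O)OC2)c1ccccc1O`, likewise gives only a limit in this assay, > 10 ug/mL. For the measured compounds named here, compound 3, `COc1ccc(C(=O)/C=C/c2ccc3c(c2)B(O)OC3)c(OC)c1`, is the one with a measured number: in this assay compound 3 gives 7.87 ug/mL. Compound 1 therefore stands together with compound 2 at the limit of > 10 ug/mL in this assay, at which 2 of the 3 values shown sit, while compound 3 alone has a value of its own.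

Compound 4, `CC(=O)Nc1ccc(C(=O)/C=C/c2ccc3c(c2)B(O)OC3)cc1`, differs from compound 1 in a single place: acetamido in place of ethyl on an aromatic carbon. Going by the values given here, no measured pair of compounds differs in just this way, so the size of the step cannot be read off from the data. With compound 1 itself giving only a limit, the step from compound 1 to compound 4 in this assay is expected to be none beyond the scatter, a step that the limit leaves unreadable from compound 1 to compound 4. Compound 4 is accordingly estimated at 15 ug/mL, in a range from 6 ug/mL to 40 ug/mL, and it may well be reported again only as a limit.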

Compound 4, half-maximal inhibitory concentration: > 10 ug/mL
Compound 4: only a limit was reported; the forecaster's own chance of this, stated with the estimate: 70%; the middle value does not contradict the limit.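

In this assay compound 4 gives > 10 ug/mL, which is a limit of the test and not a number. For the compounds shown here, compound 1 also gives only a limit, so no step between compound 1 and compound 4 can be read, and both stand at the same mark: the limit of > 10 ug/mL in this assay, at which 3 of the 4 values shown sit. The compounds shown leave open whether acetamido in place of ethyl changes cytotoxicity at all.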